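Working notes: chain variation on a shared biphenyl-acid series

The source may report more compounds than this note shows. Statements on the series, on what has been measured and on what is new or still open speak of the compounds shown alone.

Measured compounds:
compound 1 `CCC(C)(C)Cc1c[nH]c(CCc2ccc(-c3ccccc3C(=O)O)cc2)n1`: 25 nM
compound 2 `O=C(O)c1ccccc1-c1ccc(CCc2ncc(CCc3ccccc3)[nH]2)cc1`: 1320 nM

In an in vitro functional assay on cells for agonist activity at Bombesin receptor subtype-3 (Homo sapiens), read by luminescence and calcium flux (on this read-out higher numbers stand for an effect only at larger amounts of compound and lower numbers for an effect already at smaller amounts), compound 1 gives 25 nM. In this assay, for the measured compounds named here, compound 2 gives 1320 nM, the higher of the two numbers so far; the gap from compound 2 to compound 1 lies well beyond the usual scatter, and with only these two measured, nothing more can be said of what drives it.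

Compound 3 `O=C(O)c1ccccc1-c1ccc(CCc2ncc(Cc3cccc(Cl)c3)[nH]2)cc1` is not yet measured. It differs from compound 2 in one place: 3-chlorophenyl in place of benzyl on a saturated chain carbon bound to an aromatic carbon. Going by the values given here, no measured pair shows this change, and compound 1 carries a different group at the same place, so it gives no direct guide. The expectation is a small step of a 1.7-fold lower number from compound 2 to compound 3 (0.22 log units; within the scatter), towards a somewhat lower number than compound 2, but one that may not exceed the scatter.

Compound 3 is estimated at 800 nM in this assay, with a range from 200 nM to 3000 nM.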

Compound 3, half-maximal effective concentration: 825 nM
Estimate against measurement, compound 3: 1.0-fold (0.01 log units) below; low and high end bracket the measured number.
By their numbers in this assay, from the lowest: compound 1; then compounds 3 and 2 (each within the scatter of the next).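

For the compounds shown here, the step of a 1.6-fold lower number from compound 2 to compound 3 (0.20 log units; within the scatter) in this assay is the only direct reading of a single change at this place, and it stays within the scatter: 3-chlorophenyl in place of benzyl, on a saturated chain carbon bound to an aromatic carbon, keeps the count of 7 heavy atoms and the one aromatic ring, and it does not separate the two compounds. The printed values also show that compound 3, at 825 nM, remains far from compound 1, at 25 nM, so this exchange does not bring the series to the lowest number seen so far. Nothing measured on these groups bears on the result.

Since the change, read one bond further out, is phenethyl to 3-chlorobenzyl, the shorter link and the chlorine are not read apart, and the compounds shown do not tell whether either has any effect of its own at this place. Also open, as far as these compounds go, is how this place responds to groups of another kind, such as a cyclohexylmethyl group, a longer chain, or a chain ending in an amine or a carboxylic acid.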